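The source may hold more compounds than are shown below. What is called first, only, known or untested is meant among the compounds shown, and "the series" means these compounds.

Measured so far in an in vitro functional assay on HEK293-A cells for antagonist activity at metabotropic glutamate receptor 5 (Rattus norvegicus), read by calcium flux; on this read-out higher numbers stand for weaker inhibition and lower numbers for stronger inhibition:
compound 1, `O=C(Nc1cccc(NC(=O)c2cccc(Cl)c2)c1)c1ccc(Cl)cc1`: > 30000 nM
compound 2, `COc1cc(NC(=O)c2cccc(N3C(=O)c4ccccc4C3=O)c2)cc(OC)c1`: 3580 nM

Compound 1 gives > 30000 nM in this assay, and this value is a limit of the assay, not a number. Among the compounds with values here, compound 2 gives 3580 nM in this assay and is the only compound with a number. Compound 1 sits at the other kind of value: the limit of > 30000 nM in this assay, at which 1 of the 2 values shown sits.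

Compound 3, `O=C(Nc1ccccn1)c1cccc(N2C(=O)c3ccccc3C2=O)c1`, is still to be measured. It differs from compound 2 in one place: pyridin-2-yl in place of 3,5-dimethoxyphenyl on an amide-type nitrogen. Within the data shown here, no step between measured compounds exists to scale this change, so the expectation rests on compound 2 alone. The step is expected to be modest, a 1.4-fold higher number from compound 2 to compound 3 (0.15 log units; within the scatter), with no firm direction and quite possibly not beyond the scatter. Compound 3 is accordingly estimated at 5000 nM, within 1000 nM to 30000 nM.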

Compound 3, half-maximal inhibitory concentration: 1260 nM
The estimate for compound 3 lay 4.0-fold (0.60 log units) above the measured number, within the range that was stated.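

In this assay, within the data shown here, pyridin-2-yl in place of 3,5-dimethoxyphenyl on the amide-type nitrogen gives a 2.8-fold lower number from compound 2 to compound 3 (0.45 log units; beyond the scatter), the first step that can be read from two numbers. At this position, the 3,5-dimethoxyphenyl group with its 10 heavy atoms is therefore not required for inhibition, and a pyridin-2-yl group with 6 heavy atoms and a ring hetero atom serves at least as well. Nothing measured here gives a cause for this step.

Still open, from the compounds shown here alone, is whether the lower number goes with the ring nitrogen or with the loss of the methoxy groups, as this one change replaces both at once. An unsubstituted phenyl group on the same nitrogen would separate the two, and a pyridin-3-yl group would test whether the place of the ring nitrogen matters.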